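The source may hold more compounds than are shown below. What is called first, only, known or untested is meant among the compounds shown, and "the series" means these compounds.

Measured so far in an assay on membranes from lung (Cavia porcellus) for binding affinity to cysteinyl leukotriene receptor (Homo sapiens); on this read-out lower numbers stand for stronger inhibition and higher numbers for weaker inhibition:
compound 1 `c1ccc2nc(COc3ccc(CC4CCCC4Cc4nnn[nH]4)cc3)ccc2c1` gives 15 nM
compound 2 `c1ccc2nc(COc3ccc(OCCCc4nnn[nH]4)cc3)ccc2c1` gives 69 nM
compound 3 `CC(CCCC(=O)O)c1cccc(OCc2ccc3ccccc3n2)c1` gives 90 nM

Compound 2 stands second highest of the three numbers. Its nearest neighbour is compound 3, whose number is higher by a gap that lies within the scatter, so no order between compound 2 and compound 3 is claimed. Compound 1 is the furthest, with a lower number beyond the scatter.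

The next compound, compound 4 `O=C(O)CCCCc1ccc(OCc2ccc3ccccc3n2)cc1`, is not yet measured. It differs from compound 2 in one place: 4-carboxybutyl in place of 3-(1H-tetrazol-5-yl)propoxy on an aromatic carbon. The shared core of compound 2 is kept.

Among the measured compounds shown here, no step between measured compounds that differ in one place is available, so the size of the step is not known from a direct pair. The only acid among the measured compounds, compound 3, sits at 90 nM, which is in the same region as compound 2. A modest weakening, possibly beyond the scatter, is expected for compound 4, without support from a direct comparison. The expected step is a 2.2-fold higher number from compound 2 to compound 4 (0.34 log units; beyond the scatter). The estimate for compound 4 in this assay is 150 nM, with a range from 50 nM to 500 nM.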

Compound 4, inhibition constant: 110 nM
Estimate against measurement, compound 4: 1.4-fold (0.13 log units) above, within the range that was stated.
By their numbers in this assay, from the lowest: compound 1; then compounds 2, 3 and 4 (each within the scatter of the next).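

In this assay, among the compounds shown here, 4-carboxybutyl in place of 3-(1H-tetrazol-5-yl)propoxy on this aromatic carbon, para to a large group, gives a 1.6-fold higher number from compound 2 to compound 4 (0.20 log units; within the scatter), the first direct step at this position. The read-out therefore does not separate the two groups here, although the change removes the five-membered aromatic ring with 4 hetero atoms and replaces it with a chain with no ring. No measurement of any property of these two groups accompanies the result.

The step changes the acidic end group and the chain together, so a 4-(1H-tetrazol-5-yl)butyl group or a carboxylic acid joined through a chain oxygen would be needed to read each part alone. Also open, going by these compounds, is how an amine at the chain end, or a longer chain, would read at this position.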